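The source may report more compounds than this note shows. Statements on the series, on what has been measured and on what is new or still open speak of the compounds shown alone.

Values in a functional assay on the whole organism for antagonist activity, with Mus musculus as the target, in the maximal electroshock model; on this read-out higher numbers stand for an effect only at larger amounts of compound and lower numbers for an effect already at smaller amounts:
- compound 1 `COC(=O)NC1=NC(c2ccccc2)CN1C`: 107 mg/kg
- compound 2 `CC(C)COC(=O)NC1=NC(c2ccccc2)CN1C`: 70 mg/kg
- compound 3 `COC(=O)NC1=NC(c2cccc(C)c2)CN1C`: 89 mg/kg

Compound 1, at 107 mg/kg, lies within the scatter of both other measured compounds, so these three numbers give no ranking. The next compound to be measured is compound 4 `COC(=O)NC1=NC(c2ccccc2F)CN1C`. It differs from compound 1 by one change: fluoro in place of hydrogen on an aromatic carbon.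

Two measured steps start from compound 1. The closer one is also a replacement of hydrogen on an aromatic carbon, though with methyl rather than fluoro: a 1.2-fold lower number from compound 1 to compound 3 (0.08 log units; within the scatter). The other lies on the chain bound to the oxygen next to the carbonyl, so it bears on this change only as a sign of how little the numbers have moved so far: a 1.5-fold lower number from compound 1 to compound 2 (0.18 log units; within the scatter). Both steps stay within the scatter. Among the measured compounds shown here, no measured compound carries fluoro, and the data hold no example of a group at the place it occupies in compound 4. The expectation in this assay is therefore for no step beyond the scatter, in either direction.

The estimated step is a 1.1-fold lower number from compound 1 to compound 4 (0.05 log units; within the scatter), which is expected to stay within the scatter.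

For compound 4 the expected value is 95 mg/kg, with an estimated range from 50 mg/kg to 180 mg/kg.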

Compound 4, dose for half-maximal effect: 74 mg/kg
For compound 4 the middle estimate is 1.3-fold (0.11 log units) above the measured one; the range from low to high includes it.
By their numbers in this assay, from the lowest: compounds 2, 4, 3 and 1 (each within the scatter of the next).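

In this assay the first group placed on an aromatic carbon ortho to a large group, fluoro in place of hydrogen, gives a 1.4-fold lower number from compound 1 to compound 4 (0.16 log units; within the scatter) and so shows that this place on the six-membered aromatic ring accepts fluoro with no step beyond the scatter. With a 1.2-fold lower number from compound 1 to compound 3 (0.08 log units; within the scatter) as the other listed replacement on an aromatic carbon, the ring now has two single changes from compound 1, and neither leaves the scatter, so neither marks a place or a group on the ring that separates from compound 1 in this whole-organism read-out. The data contain nothing that explains the size of this step or relates it to any property of the fluoro group.

A single fluoro says little about other groups at the same place, so chloro, methoxy, trifluoromethyl or an amine there could still give a step beyond the scatter. Also open, as far as these compounds go, is whether fluoro joined with the isopropyl-bearing chain of compound 2 in one molecule would give a step beyond the scatter, since each change alone stays within it.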